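From methoxy to trifluoromethyl: does cell tolerance change?

This account rests on a few compounds, and the source may have more. Where it says the series, first, only, none or still open, it means among the compounds named here.

Compound 1 `CC(C)(C)N(Cc1ccc([N+](=O)[O-])cc1)C(=O)COC(=O)c1ccc([N+](=O)[O-])o1`: > 100000 nM (a limit)
Compound 2 `COc1ccc(CN(C(=O)COC(=O)c2ccc([N+](=O)[O-])o2)C(C)(C)C)cc1`: > 100000 nM (a limit)

In an ADME assay on MT4 cells (Homo sapiens) for cytotoxicity, read by MTT assay, with a stated time of 3 days (a higher number here means that more compound is tolerated, a lower number that less compound is tolerated), compound 2 gives > 100000 nM as a limit of the assay and not a number. Compound 1 likewise gives > 100000 nM as a limit. Both compounds share the limit of > 100000 nM in this assay, at which 2 of the 2 values shown sit, and no number is known for either.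

Compound 3 `CC(C)(C)N(Cc1cccc(C(F)(F)F)c1)C(=O)COC(=O)c1ccc([N+](=O)[O-])o1` keeps the rest of compound 2 and alters one group. The change is 3-(trifluoromethyl)phenyl in place of 4-methoxyphenyl on a saturated chain carbon bound to an amide-type nitrogen and so 3-(trifluoromethyl)phenyl stands in place of 4-methoxyphenyl on a saturated chain carbon bound to an amide-type nitrogen.

Within the data shown here, the only measured step is a step that the two limits leave unreadable from compound 1 to compound 2 and it offers no size to carry over. No step beyond the usual scatter is expected in either direction, because the limit of > 100000 nM in this assay, at which 2 of the 2 values shown sit, holds for compound 1 and compound 2 alike. The expected size of the change is an at least 1.2-fold lower number from compound 2 to compound 3 (0.09 log units; that floor lies within the scatter) as an estimate only. In this assay compound 3 is estimated at 80000 nM with an expected range from 25000 nM to 150000 nM and a limit in place of a number is also to be expected.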

Compound 3, half-maximal cytotoxic concentration: > 100000 nM
Compound 3 gave a limit, no number; the forecaster's own chance of this, stated with the estimate: 60%; at least 1.2-fold (0.09 log units) between middle value and limit.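

Compound 3 also gives a limit and not a number, so no step can be read from compound 1 or compound 2 to compound 3: the limit of > 100000 nM in this assay, at which 3 of the 3 values shown sit.

The compounds shown leave open how much of each one the cells actually tolerate, and whether the aromatic group on the saturated chain carbon makes any difference to that.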